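Swapping the Fluoromethoxyphenyl Ring for a Pyridone-Type Ring

The source may hold more compounds than are shown below. What is called first, only, known or untested is meant among the compounds shown, and "the series" means these compounds.

Compound 1 `CC(=O)N1CCC(c2cc3c(-c4ccc(=O)n(C(C)C)c4)ccnc3[nH]2)CC1` gives 2.1 in a physicochemical assay for lipophilicity, using the shake flask method, measured as octanol-water partition, at pH 7.4; a higher number here means a more lipophilic compound, a lower number a more polar compound.
Compound 2 `COc1cc(F)ccc1-c1ccnc2[nH]c(C3CCN(CC(=O)N(C)C)CC3)cc12` gives 2.9.
Compound 3 `COc1cc(F)ccc1-c1ccnc2[nH]c(C3CCN(C(C)=O)CC3)cc12` gives 3.4.

Of these three numbers compound 2 stands second highest; the nearest is a number 0.50 log units higher from compound 2 to compound 3 (beyond the scatter), and the furthest is compound 1, which lies lowest. Compound 4 `CN(C)C(=O)CN1CCC(c2cc3c(-c4ccc(=O)n(C)c4)ccnc3[nH]2)CC1` is not yet measured and differs from compound 2 in one place: a group of 8 heavy atoms (6 carbon, 1 nitrogen, 1 oxygen; one six-membered aromatic ring with 1 hetero atom) in place of a group of 9 heavy atoms (7 carbon, 1 oxygen, 1 fluorine; one six-membered aromatic ring of carbon only), on an aromatic carbon. Among the compounds with values here, the only measured step, a number 0.50 log units higher from compound 2 to compound 3 (beyond the scatter), concerns the amine nitrogen and does not bear on this aromatic change. Within the data shown here, compound 1 and compound 3 differ in two places, so no single step links them, but compound 1 carries a ring of the entering kind and sits far lower than compound 3, which carries the leaving ring. On that basis the expected step is a number 1.60 log units lower from compound 2 to compound 4 (beyond the scatter). Compound 4 is therefore estimated at 1.3, between 0.7 and 1.9.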

Compound 4, distribution coefficient: 1.1
Beside the measured number, compound 4's estimate is 0.20 log units above it; the measured number falls inside the stated range.
By their numbers in this assay, from the lowest: compound 4; then compound 1; then compound 2; then compound 3.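

Swapping the 4-fluoro-2-methoxyphenyl group on this aromatic carbon, opposite the ring nitrogen, for the entering ring gives a number 1.80 log units lower from compound 2 to compound 4 (beyond the scatter) in this assay. Within the data shown here, this is the first direct reading of a ring change at this position, and it is larger than the side-chain change on the amine nitrogen, a number 0.50 log units higher from compound 2 to compound 3 (beyond the scatter). Nothing available here accounts for the size of this step. Where a plain phenyl ring or a pyridine ring would fall at this position remains open. So does whether the ring change gives a similar step with a carboxylic acid on the side chain.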